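Orexin-1 antagonism in a triazolyl benzamide series

A few compounds are considered here, and "the series" means these few. Any claim that something is new, unique, unknown or untested is made for them only; others in the source may bear on it.

The series shares one core, an ethyl amide carrying a pyrazole-linked pyridine on one side and a triazolyl-substituted benzoyl group on the other. For the measured compounds named here, compound 1 `CCN(CCn1ccc(-c2cccc(C)n2)n1)C(=O)c1cc(C)ccc1-n1nccn1` and compound 2 `CCN(CCn1ccc(-c2ccc(F)cn2)n1)C(=O)c1cc(F)ccc1-n1nccn1` differ in two places at once, so no single step can be drawn between them. In a functional assay on CHO cells for antagonist activity at Orexin/Hypocretin receptor type 1 (Homo sapiens), read by fluorescence and calcium flux, with a stated time of 30 min (on this read-out higher numbers stand for weaker inhibition and lower numbers for stronger inhibition), compound 1 gives 0.41 nM. In this assay compound 2 gives 6.67 nM, the highest of the two numbers seen so far, standing well apart from compound 1.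

Compound 3 `CCN(CCn1ccc(-c2ccc(F)cn2)n1)C(=O)c1cc(Cl)ccc1-n1nccn1` has not yet been measured. It differs from compound 2 in one place: chloro in place of fluoro on an aromatic carbon. Nothing measured in the series shows this exact exchange, so the size of the step is open. On balance a step toward a lower number is expected, of moderate size and possibly not beyond the scatter, as a 2.7-fold lower number from compound 2 to compound 3 (0.43 log units; beyond the scatter). Compound 3 is accordingly estimated to give 2.5 nM in this assay, within a range from 0.8 nM to 8 nM.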

Compound 3, antagonist equilibrium constant: 1.48 nM
Compound 3: middle estimate off by 1.7-fold (0.23 log units), on the high side; the range from low to high includes it.
By their numbers in this assay, from the lowest: compound 1; then compound 3; then compound 2.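

In this assay, for the compounds shown here, chloro in place of fluoro, on the aromatic carbon para to the 2H-1,2,3-triazol-2-yl group, gives a 4.5-fold lower number from compound 2 to compound 3 (0.65 log units; beyond the scatter) and is the first change that can be read in one place alone. The position is therefore sensitive to which halogen it carries, with the rest of the molecule held fixed, something the two-place gap between compound 1 and compound 2 could not show; compound 1 also differs from compound 3 in two places, so no step can be read between those two. The data on hand offer no measurement that accounts for this step.

What the compounds shown leave open is how other groups at this position compare, such as bromo, methoxy or nitrile, and how much of the remaining distance to compound 1 belongs to this position at all. As far as these compounds go, it is also open whether the exchange of fluoro for chloro keeps its size when the other substituent of the shared core is methyl rather than fluoro.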